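A phenyl for a methyl on a ring nitrogen

The compounds below may be only part of what the source reports. "The series", "measured", "known", "first", "only" and "open" are said of these compounds alone.

This account concerns growth inhibition of renal carcinoma cells, measured in a functional assay on cells (Panel renal (Carcinoma cell lines), Homo sapiens) for inhibition; a lower number here means a stronger inhibitor of growth, a higher number a weaker inhibitor of growth. Of the compounds shown here, three have been measured. Compound 1 `CN1CC2=C(N=C(S)NC2c2cccs2)/C(=C/c2cccs2)C1` reaches only the limit of the assay, giving > 100000 nM in this assay. Compound 2 `COc1ccc(/C=C2\CN(C)CC3=C2OC(N)=C(C#N)C3c2ccc(OC)cc2)cc1` gives 96900 nM in this assay, a number rather than a limit. Compound 3 `CN1C/C(=C\c2cccs2)C2=NN(C)C(c3cccs3)C2C1` likewise reaches only the limit, with > 100000 nM in this assay. Among the compounds with values here, compound 3 thus stands at the limit of > 100000 nM in this assay, at which 2 of the 3 values shown sit, and no step between measured compounds is available to guide an expectation.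

Compound 4 `CN1C/C(=C\c2cccs2)C2=NN(c3ccccc3)C(c3cccs3)C2C1` differs from compound 3 in one place: phenyl in place of methyl on an amine nitrogen in a ring. The change is phenyl in place of methyl on an amine nitrogen in a ring, and nothing measured here speaks to what such a change does in this assay. With compound 3 at the limit, the step is expected to be none beyond the scatter, or at most a modest one in either direction that still leaves compound 4 near the limit. The expected step is a number no higher from compound 3 to compound 4 (the limit leaves the size open). Compound 4 is therefore expected to give about 100000 nM in this assay, within a range from 30000 nM to 300000 nM, with a real chance that only a limit is reported again.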

Compound 4, concentration for total growth inhibition: > 100000 nM
Compound 4 ended at the assay's limit (the forecaster's own chance of this, stated with the estimate: 65%); the middle value lies on the limit itself.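

Compound 3 and compound 4 both end at a limit rather than a number in this assay, so the step between them, phenyl in place of methyl on an amine nitrogen in a ring, cannot be read. The compounds shown leave open what this change does to growth inhibition, in either direction.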